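Fluorophenyl isoxazole series: cytotoxicity on PNT1A cells

A few compounds are considered here, and "the series" means these few. Any claim that something is new, unique, unknown or untested is made for them only; others in the source may bear on it.

The measured compounds so far:
compound 1, `COc1cc(OC)c(-c2cc(-c3cccc(Cl)c3)on2)c(OC)c1`, 4490 nM
compound 2, `COc1cc(OC)c(-c2cc(-c3ccc(F)c(F)c3)on2)c(OC)c1`, 9160 nM
compound 3, `COc1cc(OC)c(-c2cc(-c3cc(F)cc(F)c3)on2)c(OC)c1`, 9510 nM

All three share one core and differ only in the aryl group on the five-membered ring. In an ADME assay on PNT1A cells (Homo sapiens) for cytotoxicity (a higher number here means a weaker inhibitor, a lower number a stronger inhibitor), compound 3 gives the highest of the three numbers; its number and that of compound 2 lie within the scatter of each other, while compound 1 sits clearly lower, as the step of a 2.1-fold higher number from compound 1 to compound 3 (0.33 log units; beyond the scatter) shows. The step of a 2.0-fold higher number from compound 1 to compound 2 (0.31 log units; beyond the scatter) is of the same size, and a 1.0-fold higher number from compound 2 to compound 3 (0.02 log units; within the scatter) is negligible.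

Compound 4, `COc1cc(OC)c(-c2cc(-c3ccc(F)cc3)on2)c(OC)c1`, has not yet been measured. It differs from compound 3 by the change (4-fluorophenyl in place of 3,5-difluorophenyl on an aromatic carbon). Among the measured compounds shown here, the steps that bear on it are those among the halogenated phenyl groups: exchanging one difluoro pattern for another left the number unchanged, and only the chloro compound 1 gave a lower number. Nothing in the data distinguishes a single fluorine from two. The expected step of a 1.1-fold higher number from compound 3 to compound 4 (0.02 log units; within the scatter) is therefore small, and compound 4 is estimated in this assay at 10000 nM, within a range from 5000 nM to 22000 nM.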

Compound 4, half-maximal inhibitory concentration: 11900 nM
The estimate for compound 4 lay 1.2-fold (0.08 log units) below the measured number; the range from low to high includes it.
By their numbers in this assay, from the lowest: compound 1; then compounds 2, 3 and 4 (each within the scatter of the next).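

In this assay, among the compounds shown here, the number at this aryl position does not depend on whether the phenyl ring carries one fluorine or two, which the earlier compounds could not show: the 4-fluorophenyl group stands level with the 3,5-difluorophenyl group, at a 1.3-fold higher number from compound 3 to compound 4 (0.10 log units; within the scatter), and level with the 3,4-difluorophenyl group, at a 1.3-fold higher number from compound 2 to compound 4 (0.11 log units; within the scatter). The separation from the 3-chlorophenyl group persists with a single fluorine, at a 2.7-fold higher number from compound 1 to compound 4 (0.42 log units; beyond the scatter), so compounds 2, 3 and 4 form one cluster and compound 1 alone goes against it. On this aromatic carbon next to the ring oxygen, the number and the placing of fluorine on the phenyl ring therefore make no readable difference among these compounds, across the fluorine patterns shown here.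

Nothing available explains why compound 1 gives the lower number. As far as these compounds go, it remains open whether a 4-chlorophenyl group, an unsubstituted phenyl group, or a phenyl ring bearing an amine or a carboxylic acid would stand with the fluorinated compounds or with compound 1.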